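The source may hold more compounds than are shown below. What is called first, only, known or untested is meant among the compounds shown, and "the series" means these compounds.

Measured compounds:
Compound 1 `CC(C)c1c(C(=O)NCc2ccccc2)nn(-c2ccc(F)cc2)c1OC[C@@H](O)C[C@@H](O)CC(=O)O` gives 3.8 nM in an assay on microsomes from liver for inhibition of 3-hydroxy-3-methylglutaryl-coenzyme A reductase (Rattus norvegicus); on this read-out higher numbers stand for weaker inhibition and lower numbers for stronger inhibition.
Compound 2 `CC(C)c1c(C(=O)N(C)Cc2ccccc2)nn(-c2ccc(F)cc2)c1OC[C@@H](O)C[C@@H](O)CC(=O)O` gives 5.2 nM in this assay.

Going by the values given here, compound 2 stands at the higher of the two numbers, with compound 1 as its only neighbour, and the gap between them is within the scatter. The step that made it, a 1.4-fold higher number from compound 1 to compound 2 (0.14 log units; within the scatter), shows that adding a methyl group to the amide nitrogen changed little.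

Compound 3 `CC(C)c1c(C(=O)NCC2CCCCC2)nn(-c2ccc(F)cc2)c1OC[C@@H](O)C[C@@H](O)CC(=O)O` is not yet measured. The change is (cyclohexylmethyl)amino in place of benzyl(methyl)amino on a carbonyl carbon. Two things happen at once: the methyl on the amide nitrogen is removed again, which undoes the step from compound 1 to compound 2, and the aromatic ring of the benzyl group is swapped for a saturated six-membered ring. Only the first of these has a precedent among the measured pairs, and that precedent lies within the scatter. For the ring swap no comparison exists.

The expected step for compound 3 is therefore a 1.0-fold lower number from compound 2 to compound 3 (0.02 log units; within the scatter), small and not clearly in either direction. The estimate for compound 3 is 5 nM, with a range from 1.5 nM to 16 nM.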

Compound 3, half-maximal inhibitory concentration: 17 nM
Beside the measured number, compound 3's estimate is 3.4-fold (0.53 log units) below it; measured number outside the range, above it.
By their numbers in this assay, from the lowest: compounds 1 and 2 (each within the scatter of the next); then compound 3.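

Up to this point, the only change at this amide was the methyl on its nitrogen, and it moved the number by no more than the scatter; the new result shows that the ring on the chain matters more. In this assay, cyclohexyl in place of phenyl on a saturated chain carbon bound to an amide-type nitrogen gives a 4.5-fold higher number from compound 1 to compound 3 (0.65 log units; beyond the scatter) and the wider change of benzyl(methyl)amino to (cyclohexylmethyl)amino gives a 3.3-fold higher number from compound 2 to compound 3 (0.51 log units; beyond the scatter) so both steps point to weaker inhibition with the non-aromatic ring, though both are modest. Nothing measured here accounts for this difference.

The compounds shown leave open whether a pyridine ring would behave like phenyl or like cyclohexyl. They also leave open how a longer chain, or a methyl on the nitrogen of the cyclohexyl compound, would read.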